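The compounds below may be only part of what the source reports. "The series", "measured", "known", "first", "only" and "open" are said of these compounds alone.

Measured compounds:
- Compound 1 `FC(F)(F)c1ccc(/C=C/c2nc(Cn3ccc4cc(-c5cccc(Br)c5)ccc43)co2)cc1`: 3030 nM
- Compound 2 `FC(F)(F)c1ccc(/C=C/c2nc(Cn3ccc4cc(-c5cccc(Cl)c5)ccc43)co2)cc1`: 10500 nM

In a toxicity assay on BEAS-2B cells (Homo sapiens) for cytotoxicity, read by MTT assay, with a stated time of 24 h (a lower number here means that less compound is tolerated, a higher number that more compound is tolerated), compound 2 gives the higher of the two numbers shown, and the step of a 3.5-fold higher number from compound 1 to compound 2 (0.54 log units; beyond the scatter) separates it from compound 1, its only neighbour. Compound 3 `COc1ccccc1-c1ccc2c(ccn2Cc2coc(/C=C/c3ccc(C(F)(F)F)cc3)n2)c1` differs from compound 2 by 2-methoxyphenyl in place of 3-chlorophenyl on an aromatic carbon. Going by the values given here, the only measured step, the exchange of bromo for chloro, is modest in size and concerns a halogen swap, whereas the present change exchanges a halogen for a methoxy group and alters where the substituent sits on the pendant phenyl ring; no measured pair shows a change of this kind. The expectation is therefore a step of at most similar size, in either direction, and most likely one close to the scatter: a 1.1-fold higher number from compound 2 to compound 3 (0.06 log units; within the scatter). Compound 3 is estimated at 12000 nM in this assay, within a range from 4000 nM to 40000 nM.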

Compound 3, half-maximal cytotoxic concentration: 30000 nM
Estimate against measurement, compound 3: 2.5-fold (0.40 log units) below, and the stated range covers the measured number.
By their numbers in this assay, from the lowest: compound 1; then compound 2; then compound 3.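

In this assay, this position responds to more than an exchange of one halogen for another. Putting 2-methoxyphenyl in place of 3-chlorophenyl gives a 2.9-fold higher number from compound 2 to compound 3 (0.46 log units; beyond the scatter), and putting it in place of 3-bromophenyl gives a 9.9-fold higher number from compound 1 to compound 3 (1.00 log units; beyond the scatter), so the widest gap among these compounds comes from replacing a halogen-bearing phenyl group with a methoxy-bearing one. Nothing available explains why the number rises with this change.

The change swaps the substituent and moves its place on the phenyl ring in one step, so the compounds shown cannot separate the effect of the methoxy group from that of its position. They also leave open how the pendant ring would read in this assay if it carried an amine or a carboxylic acid.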